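Swapping the Ortho Ethoxy Group for a Nitrile

A few compounds are considered here, and "the series" means these few. Any claim that something is new, unique, unknown or untested is made for them only; others in the source may bear on it.

Measured so far:
- compound 1, `CCOc1ccccc1N1CCN(CCCCn2ncc(=O)n(C)c2=O)CC1`: 1.8 nM
- compound 2, `CN(C)c1ccccc1N1CCN(CCCCn2ncc(=O)n(C)c2=O)CC1`: 350 nM
- compound 3, `CSc1ccccc1N1CCN(CCCCn2ncc(=O)n(C)c2=O)CC1`: 1.8 nM

All three share one core and differ only in the group on the phenyl ring. In an assay for displacement of a labelled ligand from Adrenergic receptor alpha-1 (Homo sapiens) (a higher number here means a weaker inhibitor, a lower number a stronger inhibitor), compound 1 gives 1.8 nM, and compound 3 gives 1.8 nM; the two sit level with each other, together the lowest numbers here, with no change at the digits printed from compound 1 to compound 3 (within the scatter). Compound 2 stands apart, with a 190-fold higher number from compound 1 to compound 2 (2.29 log units; beyond the scatter), the largest step in the set.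

Compound 4, `Cn1c(=O)cnn(CCCCN2CCN(c3ccccc3C#N)CC2)c1=O`, has not yet been measured in this assay. It differs from compound 1 as follows: cyano in place of ethoxy on an aromatic carbon. Among the measured compounds shown here, no measured pair exchanges ethoxy for cyano, so the expectation rests on what the three measured steps show: two groups of different kind, ethoxy and methylsulfanyl, give the same number, while dimethylamino at the same place costs a great deal. Cyano is smaller than either accepted group and unlike both, so a modest loss seems more likely than none, but a large loss of the kind seen with compound 2 is not predicted.

For compound 4 the estimated step is a 5.6-fold higher number from compound 1 to compound 4 (0.74 log units; beyond the scatter), because compound 1 gives 1.8 nM. Compound 4 is therefore expected to give 10 nM, within a range from 2 nM to 60 nM.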

Compound 4, inhibition constant: 7.3 nM
Beside the measured number, compound 4's estimate is 1.4-fold (0.14 log units) above it; low and high end bracket the measured number.
By their numbers in this assay, from the lowest: compounds 1 and 3 (each within the scatter of the next); then compound 4; then compound 2.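

In this assay, the nitrile of compound 4 stays close to the ethoxy group of compound 1 (a 4.1-fold higher number from compound 1 to compound 4 (0.61 log units; beyond the scatter)) and to the methylsulfanyl group of compound 3 (a 4.1-fold higher number from compound 3 to compound 4 (0.61 log units; beyond the scatter)), yet it stands far from the dimethylamino group of compound 2 (a 48-fold lower number from compound 2 to compound 4 (1.68 log units; beyond the scatter)). The earlier compounds shown here showed only two levels at this position, one shared by compounds 1 and 3 and one far off at compound 2, whereas compound 4 adds a third level between them. Among these four compounds, a group joined to the ring through carbon therefore keeps most of the binding strength, although the change from ethoxy to cyano still has a real cost, beyond the scatter.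

Going by these compounds, it remains open whether a plain methyl group or a chlorine atom at this place would fall nearer to compound 1 or to compound 4, and whether an unsubstituted amino group would carry the heavy loss seen with compound 2. Nothing shown here gives a reason for any of these differences.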